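The source may report more compounds than this note shows. Statements on the series, on what has been measured and on what is new or still open speak of the compounds shown alone.

Measured so far:
compound 1, `O=C(CN1CCC(c2cccc[n+]2[O-])CC1)Nc1cccc(F)c1`: 70%
compound 2, `O=C(CN1CCC(c2cccc[n+]2[O-])CC1)Nc1cccc(Cl)c1Cl`: 66%

Both compounds share the same core and differ only in the aromatic group on the amide-type nitrogen. In a functional assay on HEK293 cells for agonist activity at D(4) dopamine receptor (Homo sapiens), read by FLIPR (on this read-out lower numbers stand for smaller maximal responses and higher numbers for larger maximal responses), compound 2 gives 66%, the lower of the two numbers, yet the step of a number 4 percentage points lower from compound 1 to compound 2 (within the scatter) lies within the scatter, so the two are not told apart. Compound 3, `Cc1cc(Br)ccc1NC(=O)CN1CCC(c2cccc[n+]2[O-])CC1`, is not yet measured. It differs from compound 2 as follows: 4-bromo-2-methylphenyl in place of 2,3-dichlorophenyl on an amide-type nitrogen. Going by the values given here, only one measured step exists; it swaps one halogenated aromatic group for another at the same place and was within the scatter. It does not cover 4-bromo-2-methylphenyl, so the expectation rests only on the two measured compounds lying close together. For compound 3 a step of no change at the digits printed from compound 2 to compound 3 (within the scatter) is therefore expected, none beyond the scatter. The estimated value of compound 3 in this assay is 66%, with a range from 50% to 82%.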

Compound 3, largest response reached (reported as efficacy), in percent of the reference or control that the assay uses: 61%
Compound 3: the middle estimate sits 5 percentage points above what was measured, within the range that was stated.
By their numbers in this assay, from the lowest: compounds 3, 2 and 1 (each within the scatter of the next).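

Replacing 2,3-dichlorophenyl with 4-bromo-2-methylphenyl on the amide-type nitrogen gives a number 5 percentage points lower from compound 2 to compound 3 (within the scatter) in this assay, and replacing 3-fluorophenyl with the same group gives a number 9 percentage points lower from compound 1 to compound 3 (within the scatter), so all three compounds remain indistinguishable on this read-out. Unlike the earlier step, this change brings in a ring carrying a methyl group as well as a halogen, showing that this place accepts more than a halogen-only substitution pattern without a change that can be read beyond the scatter. No measurement shown offers an explanation for this similarity.

Every aromatic group shown here still carries at least one halogen, so the response of an unsubstituted phenyl ring remains open. It is also unknown whether a group such as a carboxylic acid or an amine on this ring would keep the response in the same range.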